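The compounds below may be only part of what the source reports. "The series", "measured", "known", "first", "only" and "open" are said of these compounds alone.

In an ADME assay for permeability, using PAMPA, with a stated time of 4 h, at pH 7.4 (a lower number here means that the compound crosses the layer more slowly, a higher number that the compound crosses the layer faster), compound 1 `NCCCCN(C[C@@H]1Cc2nccnc2CN1)[C@H]1CCCc2cccnc21` gives 2 nm/s and compound 2 `NC/C=C\CN(C[C@H]1Cc2ncccc2CN1)[C@H]1CCCc2cccnc21` gives 68 nm/s as the higher of the two numbers, a gap that lies beyond the usual scatter of repeat measurements. Compound 3 `NC/C=C/CN(C[C@H]1Cc2ncccc2CN1)[C@H]1CCCc2cccnc21` departs from compound 2 in one way only (the two compounds have the same atoms and bonds and differ only in configuration as drawn: 1 of 3 stereo elements differ; a double bond is drawn Z in compound 2 and E in compound 3). Within the data shown here, no measured pair here shows what switching a double bond from Z to E does to this read-out, so the size of the step cannot be read from the data. Among the measured compounds shown here, compound 2 at 68 nm/s is the only close guide, and the expectation is no change beyond the scatter, in either direction. The expected step is a 1.1-fold lower number from compound 2 to compound 3 (0.05 log units; within the scatter) on this reading. In this assay the estimated value for compound 3 is 60 nm/s as a middle, with an expected range from 20 nm/s to 170 nm/s across repeat measurements.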

Compound 3, apparent permeability: 15 nm/s
For compound 3 the middle estimate is 4.0-fold (0.60 log units) above the measured one; measured number below the stated range.
By their numbers in this assay, from the lowest: compound 1; then compound 3; then compound 2.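

In this assay, redrawing the double bond from Z to E gives a 4.5-fold lower number from compound 2 to compound 3 (0.66 log units; beyond the scatter) and adds or removes no atom, so the geometry of this chain alone moves the read-out by more than the usual scatter. The two earlier compounds differ in more than one place and could not show this. This step can be tied to the double bond alone, and the reason lies in how the pair is built: the fact that compounds 2 and 3 differ only in the configuration as drawn.

Going by these compounds, this is a single pair on a single core, so whether the same switch gives a step of similar size on other cores remains open. Also open, on these data alone, is where a chain with a triple bond in place of the double bond, or a longer chain ending in the same amine, would fall relative to compound 2 and compound 3 .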